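Indolyl for dimethylphenyl on a shared aromatic core

The compounds below may be only part of what the source reports. "The series", "measured", "known", "first", "only" and "open" are said of these compounds alone.

Among the three measured compounds, compound 3 `COc1cc(-c2ccnc3cc(-c4ccc(C)c(C)c4)nn23)cc(OC)c1OC` holds the second highest number: in a functional assay on MCF7 cells (Homo sapiens) for inhibition, read by CCK-8 assay, with a stated time of 48 h (on this read-out lower numbers stand for stronger inhibition and higher numbers for weaker inhibition), compound 3 gives 26 nM. Its nearest neighbour is compound 1 `COc1cc(-c2ccnc3cc(-c4cn(CO)c5ccccc45)nn23)cc(OC)c1OC`, which in this assay gives 19 nM, a gap that lies within the scatter. Farthest from it is compound 2 `COc1cc(-c2ccnc3cc(-c4ccc(Cl)cc4)nn23)cc(OC)c1OC`, which in this assay gives 2320 nM.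

Compound 4 `COc1cc(-c2ccnc3cc(-c4ccc5ccn(C)c5c4)nn23)cc(OC)c1OC` differs from compound 3 at one place only: 1-methyl-1H-indol-6-yl in place of 3,4-dimethylphenyl on an aromatic carbon.

For the measured compounds named here, only one measured step touches the same place on the core. That step, an 89-fold lower number from compound 2 to compound 3 (1.95 log units; beyond the scatter), shows that the group on this aromatic carbon can move the number a long way. Going by the values given here, no step between a single six-membered ring and a fused two-ring group is on record, but compound 1, which also carries a fused two-ring group at this place, gives 19 nM, and its value and that of compound 3 sit within the scatter of each other. On that basis, compound 4 is expected to stay close to compound 3, with a 1.3-fold lower number from compound 3 to compound 4 (0.11 log units; within the scatter) a step of no more than the usual scatter. Compound 4 is therefore estimated at 20 nM, with a range from 6 nM to 70 nM.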

Compound 4, half-maximal inhibitory concentration: 74 nM
For compound 4 the middle estimate is 3.7-fold (0.57 log units) below the measured one, and the stated range ends below it.
By their numbers in this assay, from the lowest: compounds 1 and 3 (each within the scatter of the next); then compound 4; then compound 2.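

In this assay, the swap to 1-methyl-1H-indol-6-yl gives a 2.8-fold higher number from compound 3 to compound 4 (0.45 log units; beyond the scatter) and thus the first measured cost of replacing 3,4-dimethylphenyl with a fused two-ring group at this aromatic carbon, while compound 1, which also carries a fused two-ring group, gives 19 nM and compound 4 gives 74 nM in the same test, so having two fused rings here does not by itself set the number. The cost is small beside the distance from the 4-chlorophenyl compound, as a 31-fold lower number from compound 2 to compound 4 (1.50 log units; beyond the scatter) shows, so compound 4 sits much nearer compound 3 than compound 2 on this read-out, and the position tolerates a second kind of group besides 3,4-dimethylphenyl. Nothing available explains why either step has the size it has.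

The compounds shown leave open how much of the change belongs to the nitrogen-bound methyl and how much to the fused ring itself, a question that the plain 1H-indol-6-yl group would address. They also leave open how this aromatic carbon would respond to a pyridine ring or to a phenyl ring bearing a carboxylic acid.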